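Swapping the ester aryl group on compound 1

A few compounds are considered here, and "the series" means these few. Any claim that something is new, unique, unknown or untested is made for them only; others in the source may bear on it.

Compound 1 `CC1=CC[C@H]2[C@H](CC[C@]2(C)O)C(C)(C)[C@@H]1CC[C@H]1[C@]2(C)CC[C@H](OC(=O)c3ccc(Cl)cc3)C(C)(C)O[C@H]2CC[C@@]1(C)O` gives 10300 nM in a functional assay on MDA-MB-231 cells (Homo sapiens) for antiproliferative activity, read by MTT assay, with a stated time of 72 h; on this read-out higher numbers stand for weaker inhibition and lower numbers for stronger inhibition. Among the three compounds measured so far it carries the lowest number: compound 2 `CC1=CC[C@H]2[C@@H]1CC=C(C)[C@@H](CC[C@H]1[C@]3(C)CC[C@H](OC(=O)c4ccc(C)cc4)C(C)(C)O[C@H]3CC[C@@]1(C)O)C2(C)C` gives 32700 nM and compound 3 `CC1=CC[C@H]2[C@H](CC[C@]2(C)O)C(C)(C)[C@@H]1CC[C@H]1[C@]2(C)CC/C(=N/OCc3ccccc3)C(C)(C)O[C@H]2CC[C@@]1(C)O` gives 38200 nM, both of them beyond the scatter from compound 1. Compound 4 `CC1=CC[C@H]2[C@H](CC[C@]2(C)O)C(C)(C)[C@@H]1CC[C@H]1[C@]2(C)CC[C@H](OC(=O)c3ccccc3C(F)(F)F)C(C)(C)O[C@H]2CC[C@@]1(C)O` differs from compound 1 in one place: 2-(trifluoromethyl)phenyl in place of 4-chlorophenyl on a carbonyl carbon. For the measured compounds named here, no measured pair shows this change, so the size of the step rests on the structural change alone. The step from compound 1 to compound 4 is expected to be small, a 1.2-fold higher number from compound 1 to compound 4 (0.07 log units; within the scatter), in neither direction beyond the scatter. Compound 4 is estimated to give 12000 nM in this assay, within a range from 4000 nM to 40000 nM.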

Compound 4, half-maximal inhibitory concentration: 31500 nM
Compound 4: middle estimate off by 2.6-fold (0.42 log units), on the low side; the range from low to high includes it.
By their numbers in this assay, from the lowest: compound 1; then compounds 4, 2 and 3 (each within the scatter of the next).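

In this assay, for the compounds shown here, 2-(trifluoromethyl)phenyl in place of 4-chlorophenyl on a carbonyl carbon brings a 3.1-fold higher number from compound 1 to compound 4 (0.49 log units; beyond the scatter), the first step here that isolates a single change. The earlier compounds shown here differ from each other in more than one place, so they could not show that the aryl group at this position alone can move the number beyond the scatter. From the compounds shown here alone, whether a 4-(trifluoromethyl)phenyl, a methoxyphenyl or an aminophenyl group would give a similar number remains open. Nothing shown here explains the step.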